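The source may hold more compounds than are shown below. What is called first, only, known or untested is meant among the compounds shown, and "the series" means these compounds.

Three compounds of one study share a core, and a fourth has not yet been measured. Compound 1 `COC1=CC(=O)C(C)=C(CC(C)=O)C1=O` gives 2.22 ug/mL in a functional assay on MDA-MB-435 cells (Homo sapiens) for cytotoxicity, read by sulforhodamine B assay, with a stated time of 48 h; on this read-out lower numbers stand for stronger inhibition and higher numbers for weaker inhibition. Going by the values given here, compound 2 `COC1=CC(=O)C(C)=C(C[C@H](C)O)C1=O` gives 3.6 ug/mL in this assay; the step of a 1.6-fold higher number from compound 1 to compound 2 (0.21 log units; within the scatter) is the only measured step, and it concerns a change on a chain carbon. Compound 3 `COC1=CC(=O)[C@]2(C)O[C@@]23C[C@@H](C)O[C@@]13O` is the one this piece follows. In this assay compound 3 returns only a limit, > 10 ug/mL, so no number is known for it. Compound 3 is one of the values that sit at the limit of > 10 ug/mL in this assay, at which 1 of the 3 values shown sits. Compound 4 `COC1=CC(=O)[C@]2(C)O[C@@]23CC(C)OC13O` differs from compound 3 in this way: the two compounds have the same atoms and bonds; at least one stereo element is drawn with a configuration in one of them and without one in the other: 2 of 4 stereo elements differ; a stereocentre at a saturated ring carbon is drawn R in compound 3 and without a configuration in compound 4; a stereocentre at a saturated ring carbon is drawn S in compound 3 and without a configuration in compound 4. Among the compounds with values here, no measured step bears on a change of this kind, since the step from compound 1 to compound 2 concerns a different part of the molecule. Because compound 3 sits at the limit of > 10 ug/mL in this assay, at which 1 of the 3 values shown sits, compound 4 is expected to sit at a limit as well, with no step beyond the scatter, which is what a step that the limit leaves unreadable from compound 3 to compound 4 means. The estimate for compound 4 is 15 ug/mL, expected to lie between 8 ug/mL and 30 ug/mL.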

Compound 4, half-maximal inhibitory concentration: > 10 ug/mL
Compound 4: no number, only a limit; the forecaster's own chance of this, stated with the estimate: 85%; the middle value is on the limit's open side.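

No step can be read between compound 3 and compound 4, since in this assay each returns only a limit and not a number. The compounds shown leave open whether the two stereocentres drawn in compound 3 but undrawn in compound 4 affect cytotoxicity at all.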